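A few compounds are considered here, and "the series" means these few. Any claim that something is new, unique, unknown or untested is made for them only; others in the source may bear on it.

The measured compounds and their values:
compound 1 `CCNCC(=O)Nc1cc(OC)ccc1C(=O)c1ccc(OC)c2c1OC(C)(C)C=C2` gives 1980 nM
compound 2 `CCNCC(=O)Nc1cc(OC)ccc1C(=O)c1ccc(OC)c2c1C=CC(C)(C)O2` gives 4090 nM
compound 3 `COc1ccc(C(=O)c2ccc(OC)c3c2OC(C)(C)C=C3)c(NC(=O)CN(C)C)c1` gives 790 nM

All three were tested in a functional assay on A2780 cells (Homo sapiens) for antiproliferative activity, read by MTT assay, with a stated time of 48 h; a higher number here means a weaker inhibitor, a lower number a stronger inhibitor. Compound 1 and compound 2 are built from the same atoms, joined differently in their cores; the difference between the two cores is not broken down here. In this assay compound 2 has the highest number of the three, with compound 1 nearest and compound 3 furthest from it.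

Compound 1 and compound 3 differ in one place: dimethylamino in place of ethylamino on a saturated chain carbon bound to a carbonyl carbon. This change gave a 2.5-fold lower number from compound 1 to compound 3 (0.40 log units; beyond the scatter).

The fourth compound, compound 4 `COc1ccc(C(=O)c2ccc(OC)c3c2C=CC(C)(C)O3)c(NC(=O)CN(C)C)c1`, has not been measured. It stands to compound 2 exactly as compound 3 stands to compound 1: the change is dimethylamino in place of ethylamino on a saturated chain carbon bound to a carbonyl carbon, and the place is described in the same words for both pairs, so this is the same change made on the other core.

The expectation rests on a single earlier example, so it is tentative. A step of about the same size is expected, namely a 2.6-fold lower number from compound 2 to compound 4 (0.41 log units; beyond the scatter), because the same change gave a 2.5-fold lower number from compound 1 to compound 3 (0.40 log units; beyond the scatter) on the core of compound 1. On that basis compound 4 is expected to give about 1600 nM, with a likely range from 800 nM to 3300 nM.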

Compound 4, half-maximal inhibitory concentration: 3990 nM
Estimate against measurement, compound 4: 2.5-fold (0.40 log units) below; measured number above the stated range.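

In this assay, putting dimethylamino in place of ethylamino on the core of compound 2 gave a 1.0-fold lower number from compound 2 to compound 4 (0.01 log units; within the scatter), so on this core the change has no effect that can be told apart from the ordinary spread of repeated measurements. Set beside the earlier step on the core of compound 1, the result looks different, but the gap is too small to count as a real difference: the same change on two cores in this assay, a 2.5-fold lower number (0.40 log units; beyond the scatter) from compound 1 to compound 3 and a 1.0-fold lower number (0.01 log units; within the scatter) from compound 2 to compound 4, 2.4-fold (0.39 log units) apart, within the scatter of two such steps The two steps therefore do not show that the change carries over from one core to the other at the same size, and they do not show that the core alters its effect either, since one step on each core cannot separate these two readings.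

The compounds shown leave open how either core would respond to other groups in this place, such as a plain amino group, diethylamino or a morpholine ring, or to a longer chain carrying the amine. They also leave open whether further pairs made with such groups on both cores would give matching steps, which is the kind of evidence that could settle whether the core matters.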